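Acyl to sulfonyl on the ring amine nitrogen

A few compounds are considered here, and "the series" means these few. Any claim that something is new, unique, unknown or untested is made for them only; others in the source may bear on it.

Compound 1 `CN1CCN(c2ccc(C3=NN(C(=O)CCCl)C(c4ccc(N(C)C)cc4)C3)cc2)CC1` gives -0.2% in a functional assay on NCI-H1975 cells (Homo sapiens) for inhibition, read by sulforhodamine B assay, tested at 10 uM (on this read-out higher numbers stand for more inhibition at the one concentration tested (going by the name of the read-out) and lower numbers for less inhibition), and stands second highest among the three measured compounds. Its nearest neighbour is compound 2 `COC(=O)CC(=O)N1N=C(c2ccc(N3CCN(C)CC3)cc2)CC1c1ccc(N(C)C)cc1`, which gives -2.2% in this assay, a step of a number 2 percentage points lower from compound 1 to compound 2 (within the scatter). The furthest is compound 3 `CN1CCN(c2ccc(C3=NN(C(=O)c4ccc(C(F)(F)F)cc4)C(c4ccc(N(C)C)cc4)C3)cc2)CC1`, which gives 93.2%, a step of a number 93.4 percentage points higher from compound 1 to compound 3 (beyond the scatter). Compound 2 to compound 3 shows the same picture, a step of a number 95.4 percentage points higher from compound 2 to compound 3 (beyond the scatter).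

Compound 4 `CN1CCN(c2ccc(C3=NN(S(=O)(=O)c4ccc(F)cc4)C(c4ccc(N(C)C)cc4)C3)cc2)CC1` differs from compound 1 as follows: (4-fluorophenyl)sulfonyl in place of (2-chloroethyl)carbonyl on an amine nitrogen in a ring.

Within the data shown here, two measured steps bear on this change, and both were large: the gain of a number 93.4 percentage points higher from compound 1 to compound 3 (beyond the scatter) and the gain of a number 95.4 percentage points higher from compound 2 to compound 3 (beyond the scatter), each obtained when a six-membered aromatic ring with one para substituent replaced a short saturated chain on the carbonyl carbon. Among the measured compounds shown here, compound 4 likewise brings a six-membered aromatic ring to the ring nitrogen, but through a sulfonyl rather than a carbonyl, and with fluorine in place of trifluoromethyl; no measured step covers either of those two differences. The expectation is therefore a clear gain in this assay beyond the scatter, held with less confidence than the measured steps, of about a number 55.2 percentage points higher from compound 1 to compound 4 (beyond the scatter). Compound 4 is expected to give 55%, within a range of 10% to 92%.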

Compound 4, a percentage reported as inhibition, at one concentration (the size of the read-out at that concentration, not a potency): 95.7%
Compound 4: the middle estimate sits 40.7 percentage points below what was measured; measured number outside the range, above it.
By their numbers in this assay, from the lowest: compounds 2 and 1 (each within the scatter of the next); then compounds 3 and 4 (each within the scatter of the next).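

At this ring nitrogen a sulfonyl link supports the large gain as well as a carbonyl link does: in this assay the change to (4-fluorophenyl)sulfonyl gives a number 95.9 percentage points higher from compound 1 to compound 4 (beyond the scatter) and also a number 97.9 percentage points higher from compound 2 to compound 4 (beyond the scatter) on the same core. Against the aromatic acyl group the change gives a number 2.5 percentage points higher from compound 3 to compound 4 (within the scatter) so that, among these four compounds, the two groups bearing a six-membered aromatic ring (compound 3 and compound 4) stand apart from the two short saturated chains (compound 1 and compound 2), with no compound going against this split, although the swap of carbonyl for sulfonyl and of trifluoromethyl for fluorine happen together and their separate contributions cannot be read. No supporting data are available to explain this result.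

On these data alone, whether a short chain on the sulfonyl, such as methylsulfonyl, would sit with compound 1 or with compound 4 remains open, and so does the outcome for a 4-fluorobenzoyl group, which would separate the link from the ring substituent. Each compound is read at one concentration, so any difference in potency between compound 3 and compound 4 remains unresolved.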